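Cyclopropyl on the amide nitrogen: an expected tolerability

The source may report more compounds than this note shows. Statements on the series, on what has been measured and on what is new or still open speak of the compounds shown alone.

Compound 1 `CCOC(=O)/C=C/c1cnc(Nc2ccc(C#N)cc2)nc1Oc1c(C)cc(C#N)cc1C` and compound 2 `Cc1cc(C#N)cc(C)c1Oc1nc(Nc2ccc(C#N)cc2)ncc1/C=C/C(N)=O` share one core and differ by a step that the two limits leave unreadable from compound 1 to compound 2. In an ADME assay on TZM cells (Homo sapiens) for cytotoxicity, with a stated time of 1 days (a lower number here means that less compound is tolerated, a higher number that more compound is tolerated), compound 1 gives only a limit of the assay, > 227 nM. In this assay compound 2 likewise gives only a limit, > 243 nM. Compound 2 therefore stands at a limit, as shown by the limit of > 243 nM in this assay, at which 1 of the 2 values shown sits, and the step from compound 1 to compound 2 cannot be sized, since both values sit at limits, as the limit of > 227 nM in this assay, at which 1 of the 2 values shown sits, and the limit of > 243 nM in this assay, at which 1 of the 2 values shown sits, show.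

Compound 3 `Cc1cc(C#N)cc(C)c1Oc1nc(Nc2ccc(C#N)cc2)ncc1/C=C/C(=O)NC1CC1` differs from compound 2 by cyclopropyl in place of hydrogen on an amide-type nitrogen. No measured step bears on this change, and the one step shown is unreadable, so no step beyond the scatter is expected in either direction in this assay. The step from compound 2 to compound 3 is estimated as a step that the limit leaves unreadable from compound 2 to compound 3. Compound 3 is expected to give 300 nM in this assay, within a range from 150 nM to 3000 nM.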

Compound 3, half-maximal cytotoxic concentration: > 221 nM
Compound 3 gave a limit, no number (the forecaster's own chance of this, stated with the estimate: 70%); the middle value lies beyond the limit too.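

Going by these compounds alone, compound 1, compound 2 and compound 3 each give only a limit in this assay, and no step among them can be read. The compounds shown leave open the half-maximal cytotoxic concentration of each compound, and whether cyclopropyl on the amide-type nitrogen shifts it at all.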